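Moving the Thiophene Link: Three Measured, One Awaited

The compounds below may be only part of what the source reports. "The series", "measured", "known", "first", "only" and "open" are said of these compounds alone.

Of the compounds shown here, three have so far been measured in an assay on membranes from HeLa cells for displacement of a labelled ligand from adenosine receptor A3 (Homo sapiens), read by scintillation counting, with a stated time of 180 min, tested at 1 uM; a higher number here means more inhibition at the concentration tested (going by the name of the read-out), a lower number less inhibition. Compound 1 `CCCOC(=O)C1=C(C)NC(=O)NC1c1cccs1` gives 32% in this assay. Compound 2 `CCCOC(=O)C1=C(C)NC(=O)NC1c1ccsc1` differs from compound 1 in one place, (thiophen-3-yl in place of thiophen-2-yl on a saturated ring carbon), and in this assay compound 2 gives 6%, so that the step of a number 26 percentage points lower from compound 1 to compound 2 (beyond the scatter). Compound 3 `COC(=O)C1=C(C)NC(=S)NC1c1cccs1` gives 1% in this assay; its number is the lowest of the three, though its distance to compound 2 lies within the scatter and only its distance to compound 1 lies beyond it. How the core of compound 3 differs from the core of compound 1 is not broken down here.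

Compound 4 `COC(=O)C1=C(C)NC(=S)NC1c1ccsc1` has not yet been measured in this assay. It stands to compound 3 as compound 2 stands to compound 1: thiophen-3-yl in place of thiophen-2-yl on a saturated ring carbon. For the measured compounds named here, this is the same kind of change as the one between compound 1 and compound 2, not the same change: around the place, the saturated ring carbon in compound 3 is next to the ring atom that bears a methoxycarbonyl group, where in compound 1 that ring atom bears a propoxycarbonyl group. Going by the values given here, the one earlier step of this kind, a number 26 percentage points lower from compound 1 to compound 2 (beyond the scatter), lowered the number. Compound 3 gives a low number in this assay, 1%, and the step expected from it, a number 1 percentage points higher from compound 3 to compound 4 (within the scatter), is small. Compound 4 is estimated at 2% in this assay, with an expected range from 0% to 12%.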

Compound 4, a percentage reported as inhibition, at one concentration (the size of the read-out at that concentration, not a potency): 3%
Compound 4: middle estimate off by 1 percentage points, on the low side, and the stated range covers the measured number.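

On the second core, the move from thiophen-2-yl to thiophen-3-yl gave a number 2 percentage points higher from compound 3 to compound 4 (within the scatter) in this assay and so did not repeat the earlier fall; the two steps differ: the same change on two cores in this assay, a number 26 percentage points lower (beyond the scatter) from compound 1 to compound 2 and a number 2 percentage points higher (within the scatter) from compound 3 to compound 4, 28 percentage points apart, beyond the scatter of two such steps. This shows that, in these two pairs, the size of the step seen on the core of compound 1 does not carry over to the core of compound 3. It does not show that the two thiophene attachments are equivalent on the second core, since compound 3 already gives 1% and a fall of the earlier size could not appear from so low a starting number, nor does it show which difference between the two cores goes with the different outcome.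

The compounds shown leave open how a ring without sulfur, such as furan-2-yl or phenyl, would read on the saturated ring carbon, and whether a butoxycarbonyl group would read differently from propoxycarbonyl and methoxycarbonyl. They also leave open how the same thiophene change would behave on a core that differs from the core of compound 1 in one place only, which is what would be needed to tie the lost effect to a single feature.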